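Replacing pyridin-3-yl with a trifluoromethyl-substituted thiophene

The compounds below may be only part of what the source reports. "The series", "measured", "known", "first", "only" and "open" are said of these compounds alone.

Measured in an assay on CHO cells for displacement of a labelled ligand from melanin-concentrating hormone receptor 1 (Homo sapiens), read by scintillation counting, with a stated time of 1 h; on this read-out higher numbers stand for weaker inhibition and lower numbers for stronger inhibition:
compound 1 `Cc1c(C2CC2)nc2ccc(-n3ccc(OCc4ccc(F)cc4)cc3=O)cn12` gives 47 nM.
compound 2 `Cc1c(C2CC2)nc2ccc(-n3ccc(OCc4ccc(C(C)C)cc4)cc3=O)cn12` gives 410 nM.
compound 3 `Cc1c(C2CC2)nc2ccc(-n3ccc(OCc4cccnc4)cc3=O)cn12` gives only a limit of the assay, > 1000 nM.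

On the numbers shown compound 3 stands last of the three; its value is a limit, not a number (the limit of > 1000 nM in this assay, at which 1 of the 3 values shown sits). Both steps leading into it lie beyond the scatter: an at least 21-fold higher number from compound 1 to compound 3 (1.32 log units; beyond the scatter) and an at least 2.4-fold higher number from compound 2 to compound 3 (0.38 log units; beyond the scatter). Between the two phenyl-bearing compounds, an 8.7-fold higher number from compound 1 to compound 2 (0.94 log units; beyond the scatter).

Compound 4 `Cc1c(C2CC2)nc2ccc(-n3ccc(OCc4csc(C(F)(F)F)c4)cc3=O)cn12` differs from compound 3 by 5-(trifluoromethyl)thiophen-3-yl in place of pyridin-3-yl on a saturated chain carbon bound to an oxygen on an aromatic ring. Among the measured compounds shown here, no measured pair covers this step directly. The steps from compound 1 and compound 2 to compound 3 show that the two phenyl-bearing compounds are stronger than compound 3, and the entering group is again a substituted carbocycle-like aromatic ring rather than pyridin-3-yl. Since compound 3 is a limit, any step from it can only be bounded from below. A lower number in this assay is expected for compound 4, by a step estimated as an at least 6.6-fold lower number from compound 3 to compound 4 (0.82 log units; beyond the scatter), with compound 2 as a caution that substituted rings here can also sit well above compound 1. The estimate for compound 4 is 150 nM, with a range from 40 nM to 600 nM.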

Compound 4, half-maximal inhibitory concentration: 17 nM
For compound 4 the middle estimate is 8.8-fold (0.95 log units) above the measured one; measured number below the stated range.
By their numbers in this assay, from the lowest: compound 4; then compound 1; then compound 2. At a limit, above all of these: compound 3.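

In this assay, the step to 5-(trifluoromethyl)thiophen-3-yl shows that this place on the saturated chain carbon bound to an oxygen on an aromatic ring can hold a group that improves on 4-fluorophenyl, with a 2.8-fold lower number from compound 1 to compound 4 (0.44 log units; beyond the scatter), and that a substituted ring need not cost strength as 4-isopropylphenyl does, with a 24-fold lower number from compound 2 to compound 4 (1.38 log units; beyond the scatter). The five-membered ring also recovers all that was lost with pyridin-3-yl and more, with an at least 58-fold lower number from compound 3 to compound 4 (1.76 log units; beyond the scatter). The value of compound 3 is a limit of the assay, not a number: the limit of > 1000 nM in this assay, at which 1 of the 4 values shown sits.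

The compounds shown leave open whether the gain belongs to the thiophene ring or to the trifluoromethyl group, as both enter in the same step and neither an unsubstituted thiophen-3-yl nor a 4-(trifluoromethyl)phenyl group stands among them. Also open, on these data alone, is how far the result carries to other groups on the thiophene ring, such as a chloro, a methyl or a nitrile in place of trifluoromethyl, and whether it holds with a different link than the oxygen and its saturated chain carbon.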